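The compounds below may be only part of what the source reports. "The series", "measured", "known", "first", "only" and "open" are said of these compounds alone.

Measured compounds, all in an assay on HEK293 cells for inhibition of transient receptor potential cation channel subfamily M member 8 (Homo sapiens), read by FLIPR and calcium flux; on this read-out lower numbers stand for stronger inhibition and higher numbers for weaker inhibition:
Compound 1, `CCCCN(C(=O)c1ccccc1OCc1ccccc1)[C@@H]1CCC[C@H](N)C1`, gives 1400 nM.
Compound 2, `N[C@H]1CCC[C@@H](N(CC2CC2)C(=O)c2ccccc2OCc2ccccc2)C1`, gives 593 nM.
Compound 3, `CCN(C(=O)c1ccccc1OCc1cccc(Cl)c1)C1CCCC(N)C1`, gives 96.9 nM.

Compound 3 stands lowest of the three numbers; compound 2 is nearest, and compound 1 furthest. Going by the values given here, the only single-place step among the measured compounds is a 2.4-fold lower number from compound 1 to compound 2 (0.37 log units; beyond the scatter), a change on the amide-type nitrogen rather than on the benzyl ether, so it does not bear on the change at hand. Among the compounds with values here, compounds 1 and 2 differ from compound 3 in more than one place, so their values show only that compound 3 sits well below both.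

Compound 4, `CCN(C(=O)c1ccccc1OCc1ccc(C#N)cc1)C1CCCC(N)C1`, differs from compound 3 by 4-cyanophenyl in place of 3-chlorophenyl on a saturated chain carbon bound to an oxygen on an aromatic ring. Within the data shown here, no measured step touches the benzyl group, so the expectation rests on compound 3 alone and carries wide uncertainty; the estimate leans toward a somewhat higher number, the exchange of a halogen for a nitrile on this ring being untested. The expected step is a 2.6-fold higher number from compound 3 to compound 4 (0.41 log units; beyond the scatter). For compound 4 the estimate in this assay is 250 nM, with a range from 60 nM to 1000 nM.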

Compound 4, half-maximal inhibitory concentration: 6780 nM
Beside the measured number, compound 4's estimate is 27-fold (1.43 log units) below it; the measured number lies above the stated range.
By their numbers in this assay, from the lowest: compound 3; then compound 2; then compound 1; then compound 4.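

Going by these compounds alone, at the benzyl ether position, this assay is strongly sensitive to the aryl group: 4-cyanophenyl in place of 3-chlorophenyl gives a 70-fold higher number from compound 3 to compound 4 (1.84 log units; beyond the scatter), the first reading of a change at this place. The change is therefore far from neutral here, and the 3-chlorobenzyl of compound 3 is clearly preferred to the 4-cyanobenzyl of compound 4 on this read-out. The data on hand offer no explanation for a step of this size.

Going by these compounds, this single step swaps the substituent and its ring location together, so it remains open which of the two carries the loss. A 4-chlorophenyl or a 3-cyanophenyl at the same place, on the core of compound 3, would separate them.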